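Removing a Nitro Group: Expected Paw Edema Inhibition

The compounds below may be only part of what the source reports. "The series", "measured", "known", "first", "only" and "open" are said of these compounds alone.

Compound 1 `O=C(CO[N+](=O)[O-])NNC(=O)c1ccc(-n2[nH]c(=O)cc2-c2ccc(Cl)cc2)cc1`: 11.5%
Compound 2 `CCOC(=O)c1c(-c2ccc([N+](=O)[O-])cc2)n(-c2ccc(C(=O)NNC(=O)CO[N+](=O)[O-])cc2)[nH]c1=O`: 28.1%

In a functional assay on the whole organism (strain Wistar) for inhibition, with Rattus norvegicus as the target, read by paw edema, with stated times of 2 h and 1 h, at a dose of 6 mg/kg by the oral route (a lower number here means less inhibition, a higher number more inhibition at the dose given (going by the name of the read-out)), compound 2 stands at the higher of the two numbers, while compound 1 gives 11.5%, a value lying beyond the scatter below it. Among the measured compounds shown here, no single-point step between the measured compounds is defined, so this gap is read only as what the two values show. Compound 3 `CCOC(=O)c1c(-c2ccccc2)n(-c2ccc(C(=O)NNC(=O)CO[N+](=O)[O-])cc2)[nH]c1=O` differs from compound 2 in one place: hydrogen in place of nitro on an aromatic carbon. For the measured compounds named here, with no measured pair carrying this change, the step of a number 6.1 percentage points lower from compound 2 to compound 3 (within the scatter) is expected to be small, without a firm direction, and probably within the scatter. Compound 3 is thus estimated at 22%, with a range from 8% to 36%.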

Compound 3, a percentage reported as inhibition, in the whole organism at one dose (the size of the read-out at that dose, not a potency): 57.8%
Compound 3: the middle estimate sits 35.8 percentage points below what was measured, and the stated range ends below it.
By their numbers in this assay, from the lowest: compound 1; then compound 2; then compound 3.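

Taking 4-nitrophenyl to phenyl, with hydrogen in place of nitro, brings a number 29.7 percentage points higher from compound 2 to compound 3 (beyond the scatter) in this assay. Among the compounds shown here, this is the first single-place change, and it shows that what sits on this aromatic carbon, para to a large group, matters to inhibition at the dose given, with the unsubstituted phenyl ahead of the 4-nitrophenyl. No measured evidence accounts for this step. The compounds shown leave open whether another group at this place, such as an amine or a methoxy group, would match hydrogen or nitro. They also leave open whether the step holds on a core without the ethyl ester.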